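Chain extension on two indole cores: lipophilicity notes

A few compounds are considered here, and "the series" means these few. Any claim that something is new, unique, unknown or untested is made for them only; others in the source may bear on it.

Measured so far:
Compound 1, `CCc1cccc2c(C3=C(Br)C(=O)NC3=O)c(-c3ccc(OC)cc3)[nH]c12`: 3.35
Compound 2, `CCCCc1cccc2c(C3=C(Br)C(=O)NC3=O)c(-c3ccc(OC)cc3)[nH]c12`: 3.81
Compound 3, `CCOc1ccc2[nH]c(-c3cccc(OC)c3)c(C3=C(Br)C(=O)NC3=O)c2c1`: 2.97

In a physicochemical assay for lipophilicity (on this read-out higher numbers stand for higher lipophilicity and lower numbers for lower lipophilicity), compound 3 stands lowest of the three measured compounds, with compound 1 nearest and compound 2 furthest, both differences beyond the scatter. The difference between the core of compound 1 and the core of compound 3 is not broken down here.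

Within the first core, compound 1 and compound 2 differ in one place: ethyl in place of hydrogen on a saturated chain carbon, two bonds along the chain from an aromatic carbon. This step gives a number 0.46 log units higher from compound 1 to compound 2 (beyond the scatter).

Compound 4, `CCCCOc1ccc2[nH]c(-c3cccc(OC)c3)c(C3=C(Br)C(=O)NC3=O)c2c1`, has not yet been measured in this assay. It differs from compound 3 in one place: ethyl in place of hydrogen on a saturated chain carbon, two bonds along the chain from an oxygen on an aromatic ring. This is the same kind of change as that from compound 1 to compound 2, but not the same: in the first pair the chain carbon sits two bonds along the chain from an aromatic carbon, whereas in the second pair it sits two bonds along the chain from an oxygen on an aromatic ring.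

For compound 4 the expected step from compound 3 is a number 0.53 log units higher from compound 3 to compound 4 (beyond the scatter), resting on the measured step from compound 1 to compound 2 in this assay. Compound 4 is therefore estimated at 3.5, with a likely range from 3.1 to 3.9.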

Compound 4, partition coefficient: 3.46
For compound 4 the middle estimate is 0.04 log units above the measured one, and the stated range covers the measured number.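

In this assay the ethoxy to butoxy change gives a number 0.49 log units higher from compound 3 to compound 4 (beyond the scatter) and the ethyl to butyl change on the core of compound 1 gives a number 0.46 log units higher from compound 1 to compound 2 (beyond the scatter) so the same kind of chain extension gives a step in the same direction on both cores, each beyond the scatter. This holds across the two attachments shown, with the extended carbon two bonds along the chain from an aromatic carbon in one pair and from an oxygen on an aromatic ring in the other, and neither pair goes against it. It rests on only these two pairs, however, so it sets no general rule for carrying the change to other cores, and nothing available bears on why the two steps run alike.

The compounds shown leave open whether the step continues in the same way for a longer chain such as hexyl, or whether it survives when the chain ends in an amine or a carboxylic acid. They also leave open whether a branched chain such as isobutyl, in place of the straight butyl or butoxy chain, would give a step of similar size on either core.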